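A small step from allyloxy to butoxy

The compounds below may be only part of what the source reports. "The series", "measured", "known", "first", "only" and "open" are said of these compounds alone.

compound 1 `COc1cc(/C=C/C(=O)c2ccc(C3CCCCC3)cc2)cc(OC)c1`: 39000 nM
compound 2 `COc1cc(/C=C/C(=O)c2ccc([N+](=O)[O-])cc2)cc(OC)c1`: 20000 nM
compound 3 `C=CCOc1ccc(C(=O)/C=C/c2cc(OC)cc(OC)c2)cc1`: 25000 nM

In a functional assay (Homo sapiens) for inhibition (on this read-out higher numbers stand for weaker inhibition and lower numbers for stronger inhibition), compound 3 gives 25000 nM and sits among the other two values, with a 1.6-fold lower number from compound 1 to compound 3 (0.19 log units; within the scatter) and a 1.3-fold higher number from compound 2 to compound 3 (0.10 log units; within the scatter). Compound 4 `CCCCOc1ccc(C(=O)/C=C/c2cc(OC)cc(OC)c2)cc1` turns allyloxy into butoxy, which is propyl in place of vinyl on a saturated chain carbon bound to an oxygen on an aromatic ring. Among the compounds with values here, no measured step covers this exact swap. The closest evidence comes from swaps of the whole group, and even a 2.0-fold lower number from compound 1 to compound 2 (0.29 log units; within the scatter) stays inside the scatter. No step beyond the scatter is therefore expected in this assay, and no direction can be called. The estimated step is a 1.0-fold higher number from compound 3 to compound 4 (0.02 log units; within the scatter). For compound 4 the estimate is 26000 nM, with an expected range from 13000 nM to 50000 nM.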

Compound 4, half-maximal inhibitory concentration: 52000 nM
Compound 4: middle estimate off by 2.0-fold (0.30 log units), on the low side; measured number outside the range, above it.
By their numbers in this assay, from the lowest: compounds 2, 3, 1 and 4 (each within the scatter of the next, the first and the last beyond it).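

Within the data shown here, every earlier swap at this position stayed inside the scatter, whereas in this assay the change from allyloxy to butoxy gives a 2.1-fold higher number from compound 3 to compound 4 (0.32 log units; beyond the scatter) and so is the first to clear it. Against nitro, butoxy gives a 2.6-fold higher number from compound 2 to compound 4 (0.41 log units; beyond the scatter) while against cyclohexyl it gives a 1.3-fold higher number from compound 1 to compound 4 (0.12 log units; within the scatter) and so does not clear the scatter. A small edit at the chain end can therefore register here, though only modestly.

Nothing measured here explains the step. From the compounds shown here alone, whether the lost double bond or the added carbon counts more stays open, as does how propoxy, a longer chain such as hexyloxy, or a chain ending in an amine would read.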